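Replacing the carboxy group of compound 2

The compounds below may be only part of what the source reports. "The series", "measured", "known", "first", "only" and "open" are said of these compounds alone.

Measured values (a functional assay on MCF7 cells (Homo sapiens) for cytotoxicity, read by MTT assay, with a stated time of 72 h; a higher number here means a weaker inhibitor, a lower number a stronger inhibitor):
Compound 1 (`CCOC(=O)c1c(C)oc2ncnc(Nc3cccc(C)c3)c12`): > 1000000 nM (a limit of the assay, not a number)
Compound 2 (`Cc1oc2ncnc(Nc3cccc(Br)c3)c2c1C(=O)O`): 68000 nM
Compound 3 (`Cc1cccc(Nc2ncnc3oc(C)c(CO)c23)c1`): 17000 nM

Compound 2 (68000 nM) has a higher number than compound 3 (17000 nM) in this assay and is therefore the weaker inhibitor of the two. Compound 4 (`Cc1oc2ncnc(Nc3cccc(Br)c3)c2c1C(=O)NCCO`) carries (2-hydroxyethyl)amino in place of hydroxy on a carbonyl carbon. Among the measured compounds shown here, only one measured step bears on this, and only loosely: hydroxymethyl in place of ethoxycarbonyl on an aromatic carbon (an at least 58-fold lower number from compound 1 to compound 3 (1.76 log units; beyond the scatter)). That step is large, but it is a different change and one end of it is a limit (the limit of > 1000000 nM in this assay, at which 1 of the 3 values shown sits). The expected change is therefore a slight rise that stays within the scatter (a 1.3-fold higher number from compound 2 to compound 4 (0.12 log units; within the scatter)). Compound 4 is estimated at 90000 nM with an expected range from 20000 nM to 500000 nM in this test.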

Compound 4, half-maximal inhibitory concentration: 22000 nM
Compound 4: the middle estimate sits 4.1-fold (0.61 log units) above what was measured, within the range that was stated.
By their numbers in this assay, from the lowest: compounds 3 and 4 (each within the scatter of the next); then compound 2. At a limit, above all of these: compound 1.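

In this assay, putting (2-hydroxyethyl)amino in place of hydroxy on this carbonyl carbon gives a 3.1-fold lower number from compound 2 to compound 4 (0.49 log units; beyond the scatter), a modest step. The carboxy group is therefore not required here, and the larger (2-hydroxyethyl)carbamoyl group is tolerated on the same core. No measurement shown gives a cause for this step.

As far as these compounds go, whether the terminal hydroxy of the chain matters remains open. A plain ethylamino group, or a longer chain ending in an amine, at the same carbonyl carbon would help to settle that.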